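This account rests on a few compounds, and the source may have more. Where it says the series, first, only, none or still open, it means among the compounds named here.

Compound 2 `C#CCNC1CCc2c(OCCCCN3CCN(c4cccc5c4ccn5Cc4cccc(Cl)c4)CC3)cccc21` is one of three close relatives measured in an assay on HEK293 cells for displacement of a labelled ligand from 5-hydroxytryptamine receptor 6 (Homo sapiens), read by scintillation counting, with a stated time of 1 h; a higher number here means a weaker inhibitor, a lower number a stronger inhibitor; compound 2 gives 113 nM. Compound 1 `C#CCNC1CCc2c(OCCCN3CCN(c4cccc5c4ccn5Cc4cccc(Cl)c4)CC3)cccc21` gives 77 nM in this assay, a number within the scatter of that of compound 2, so the two cannot be told apart. Compound 3 `C#CCNC1CCc2c(OCCCCCCN3CCN(c4cccc5c4ccn5Cc4cccc(Cl)c4)CC3)cccc21` gives 259 nM, a higher number than compound 2 that lies beyond the scatter. Compound 4 `C#CCNC1CCc2c(OCCCCN3CCN(c4cccc5c4ccn5S(=O)(=O)c4ccccc4)CC3)cccc21` keeps the longer chain of compound 2 but carries phenylsulfonyl in place of 3-chlorobenzyl on an aromatic nitrogen. Among the measured compounds shown here, no measured pair covers such a swap, so the expected size of the step is uncertain; a modest move toward a lower number is expected. From this, compound 4 is estimated at 60 nM in this assay, within a range from 15 nM to 250 nM, which means an expected step of a 1.9-fold lower number from compound 2 to compound 4 (0.27 log units; within the scatter).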

Compound 4, inhibition constant: 50 nM
Compound 4: middle estimate off by 1.2-fold (0.08 log units), on the high side, within the range that was stated.
By their numbers in this assay, from the lowest: compounds 4, 1 and 2 (each within the scatter of the next, the first and the last beyond it); then compound 3.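

Among the compounds shown here, the earlier compounds differed only in chain length, so compound 4 is the first to show that the group on the aromatic nitrogen also matters in this assay: phenylsulfonyl in place of 3-chlorobenzyl gives a 2.3-fold lower number from compound 2 to compound 4 (0.35 log units; beyond the scatter). The swap brings in two hydrogen-bond acceptors and removes the chlorine, but nothing available shows what lies behind the step. Going by these compounds, whether a benzoyl or methylsulfonyl group on this nitrogen would give a similar number remains open. So does whether phenylsulfonyl would give the same step on the shorter chain of compound 1 or the longer chain of compound 3.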